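Moving the chlorine on the sulfonyl aryl ring

This account rests on a few compounds, and the source may have more. Where it says the series, first, only, none or still open, it means among the compounds named here.

Of the compounds shown here, three have been tested in an assay on cells for inhibition of HSP60/HSP10 (Homo sapiens), with a stated time of 60 min; on this read-out higher numbers stand for weaker inhibition and lower numbers for stronger inhibition. Compound 1 `O=S(=O)(Nc1ccc(-c2nc3ccccc3o2)cc1)c1cccc(Cl)c1` gives 54000 nM. Compound 2 `O=S(=O)(Nc1ccc2oc(-c3ccccc3)nc2c1)c1cccs1` gives 90000 nM, and compound 3 `O=S(=O)(Nc1ccc2oc(-c3ccccc3)nc2c1)c1ccc(O)cc1` gives 88000 nM. Compound 1 has the lowest of the three numbers, yet its gaps to compound 3 and to compound 2 both fall within the scatter of repeated measurements, so the three cannot be told apart with confidence.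

Going by the values given here, the only measured step that changes the group on the sulfonyl sulfur is a 1.0-fold lower number from compound 2 to compound 3 (0.01 log units; within the scatter): exchanging that group gave a number within the scatter.

Compound 4 `O=S(=O)(Nc1ccc(-c2nc3ccccc3o2)cc1)c1ccc(Cl)cc1` has not yet been measured. It differs from compound 1 in one place: 4-chlorophenyl in place of 3-chlorophenyl on a sulfonyl sulfur. Among the compounds with values here, no measured pair shows exactly this shift of the chlorine, and the one step on the sulfonyl sulfur, from compound 2 to compound 3, stayed within the scatter. In this assay a step no larger than the scatter, in either direction, is therefore expected. Compound 4 is expected to give 55000 nM, with a likely range from 22000 nM to 140000 nM. That estimate corresponds to a 1.0-fold higher number from compound 1 to compound 4 (0.01 log units; within the scatter).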

Compound 4, half-maximal inhibitory concentration: 61000 nM
For compound 4 the middle estimate is 1.1-fold (0.04 log units) below the measured one, within the range that was stated.
By their numbers in this assay, from the lowest: compounds 1, 4, 3 and 2 (each within the scatter of the next).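

In this assay, moving the chlorine so that 4-chlorophenyl replaces 3-chlorophenyl on the sulfonyl sulfur gives a 1.1-fold higher number from compound 1 to compound 4 (0.05 log units; within the scatter). Going by these compounds alone, this is the first measured pair with the same atoms joined differently, and it shows that on the core of compound 1 these two placements of the chlorine cannot be told apart, just as exchanging the whole group on the sulfur on the core of compound 2 gave a 1.0-fold lower number from compound 2 to compound 3 (0.01 log units; within the scatter). Nothing available explains why either change leaves the number within the scatter.

On these data alone, what remains open is whether any group on the sulfonyl sulfur can move the number beyond the scatter, for example an amine or a carboxylic acid on the phenyl ring, an unsubstituted phenyl, or a longer alkyl chain in place of the ring. Also open is whether a change on the sulfur carries over from the core of compound 1 to the core of compound 2, since the pairs shown each stay on one core.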